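Swapping dimethylamino for isopropyl on a biaryl scaffold

A few compounds are considered here, and "the series" means these few. Any claim that something is new, unique, unknown or untested is made for them only; others in the source may bear on it.

Of the compounds shown here, three that share one core have been measured in a physicochemical assay for lipophilicity, read by HPLC, at pH 7.5; a higher number here means a more lipophilic compound, a lower number a more polar compound. Compound 1 `CCOc1ccccc1-c1ccc(-c2nc3cncc(Cl)c3c(N[C@H](CC)C(N)=O)c2C#N)cc1` gives 3.7. Compound 2 `CC[C@@H](Nc1c(C#N)c(-c2ccc(-c3ccccc3N(C)C)cc2)nc2cnccc12)C(N)=O` gives 3.2. Compound 3 `CCOc1ccccc1-c1ccc(-c2nc3cnccc3c(N[C@@H]3CCOC3=O)c2C#N)cc1` gives 2.7. Compound 2 thus stands in the middle of the three numbers: compound 1 sits higher by an amount beyond the scatter, and compound 3 sits lower by an amount beyond the scatter. Among the compounds with values here, no pair of these three differs in only one place, so none of the gaps between them can be tied to a single structural change.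

Compound 4 `CC[C@@H](Nc1c(C#N)c(-c2ccc(-c3ccccc3C(C)C)cc2)nc2cnccc12)C(N)=O` has not yet been measured. It differs from compound 2 in one place only: isopropyl in place of dimethylamino on an aromatic carbon. Seen one bond further out, the change reads 2-(dimethylamino)phenyl to 2-isopropylphenyl.

Within the data shown here, since no single-change step between measured compounds is available, the expectation for compound 4 rests on the counted change alone. The step from compound 2 to compound 4 is expected to be upward and beyond the scatter, a number 1.10 log units higher from compound 2 to compound 4 (beyond the scatter), because compound 2 starts from 3.2. Compound 4 is therefore estimated at 4.3 in this assay, with a likely range from 3.8 to 4.8.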

Compound 4, distribution coefficient: 3.5
Compound 4: the middle estimate sits 0.80 log units above what was measured; the whole stated range lies above it.
By their numbers in this assay, from the lowest: compound 3; then compounds 2, 4 and 1 (each within the scatter of the next, the first and the last beyond it).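

In this assay, putting isopropyl in place of dimethylamino on this aromatic carbon, ortho to a large group, gives a number 0.30 log units higher from compound 2 to compound 4 (within the scatter) and so leaves compound 2 and compound 4 indistinguishable in this measurement. By the count of atoms, the change takes out a nitrogen and its one hydrogen-bond acceptor and puts in an all-carbon group of the same 3 heavy atoms, yet this single exchange at this one position does not produce a difference that can be separated from the ordinary spread of repeat readings. Nothing available bears on why the two groups read alike here.

What remains open is how far this holds at the same position for groups of a different kind, such as a carboxylic acid, a primary amine or a longer alkyl chain, none of which appears among these compounds. The exchange is also seen only once, on the core of compound 2, so whether it would read the same way on another core cannot be told from this single pair.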